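This account rests on a few compounds, and the source may have more. Where it says the series, first, only, none or still open, it means among the compounds named here.

Measured so far:
compound 1, `Clc1ccccc1Cn1nnc2c(NC3CCCC3)nc(-c3ccccc3)nc21`, 9 nM
compound 2, `OCCNc1nc(-c2ccccc2)nc2c1nnn2Cc1ccccc1`, 38 nM

Within the data shown here, the two measured compounds share a core and differ in two places at once, so no single step between them is defined. In an assay on Cerebral cortex for displacement of a labelled ligand from adenosine receptor A1 (Bos taurus) (on this read-out higher numbers stand for weaker inhibition and lower numbers for stronger inhibition), compound 2 gives 38 nM, the higher of the two numbers; compound 1 gives 9 nM, a lower number, and the gap between them lies beyond the usual scatter. Compound 3, `OCCNc1nc(-c2ccccc2)nc2c1nnn2Cc1ccccc1Cl`, has not been measured. It follows from compound 2 by one change, (chloro in place of hydrogen on an aromatic carbon), which reads one bond further out as benzyl to 2-chlorobenzyl. Compound 1 carries that same 2-chlorobenzyl but also a cyclopentylamino group in place of the hydroxyethylamino group of compound 2, so its lower number cannot be assigned to the chloro alone. A step of modest size toward a lower number is expected for compound 3, and the estimate of a 1.9-fold lower number from compound 2 to compound 3 (0.28 log units; within the scatter) is set so that a result within the scatter of compound 2 also remains possible. For compound 3 a value of 20 nM is therefore expected, in the range from 7 nM to 60 nM.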

Compound 3, inhibition constant: 116 nM
Beside the measured number, compound 3's estimate is 5.8-fold (0.76 log units) below it; measured number outside the range, above it.
By their numbers in this assay, from the lowest: compound 1; then compound 2; then compound 3.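

In this assay, chloro in place of hydrogen on an aromatic carbon, ortho to a large group, gives a 3.1-fold higher number from compound 2 to compound 3 (0.48 log units; beyond the scatter), so with the 2-hydroxyethyl group on the nitrogen this change moves the number toward weaker inhibition, not toward stronger inhibition. With 2-chlorobenzyl held constant, 2-hydroxyethyl in place of cyclopentyl on a nitrogen on an aromatic ring gives a 13-fold higher number from compound 1 to compound 3 (1.11 log units; beyond the scatter), a large step that ties the low number within this 2-chlorobenzyl pair to the cyclopentyl group and not to the chloro. Nothing at hand explains why the chloro raises the number at this position.

The compounds shown leave open whether the chloro step has the same direction and size when cyclopentyl sits on the nitrogen, so the two changes cannot yet be treated as independent of each other. They also leave open whether a fluoro or a methyl group in place of the chloro would raise the number as well, and whether an amine or a longer chain in place of the 2-hydroxyethyl group would bring it closer to that seen with cyclopentyl.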